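Inverting one ring stereocentre in an oxygen-bridged EP3 agonist

A few compounds are considered here, and "the series" means these few. Any claim that something is new, unique, unknown or untested is made for them only; others in the source may bear on it.

Measured compounds:
- compound 1, `O=C(O)CCCCC1=CC[C@@H]2[C@@H](/C=C/[C@@H](O)COc3ccccc3)[C@H](O)C[C@@H]2OC1`, 13 nM
- compound 2, `O=C(O)CCC[C@H]1CC[C@@H]2[C@@H](/C=C/[C@@H](O)COc3ccccc3)[C@H](O)C[C@@H]2OC1`, 4 nM
- compound 3, `O=C(O)CC[C@@H]1CCC[C@@H]2[C@@H](/C=C/[C@@H](O)COc3ccccc3)[C@H](O)C[C@@H]2O1`, 27 nM

Three compounds share the phenoxy-bearing side chain and the bicyclic core and differ in how the acid-bearing chain is attached. In a functional assay on CHO cells for agonist activity at prostaglandin E2 receptor EP3 subtype (Homo sapiens), read by fluorescence and calcium flux (a lower number here means that less compound is needed, a higher number that more compound is needed for the effect), compound 3 gives 27 nM, the highest of the three numbers. Compound 1 gives 13 nM in this assay, a lower number than compound 3 by a margin beyond the scatter, and compound 2 gives 4 nM, the lowest of the three and further still from compound 3.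

Compound 4, `O=C(O)CC[C@H]1CCC[C@@H]2[C@@H](/C=C/[C@@H](O)COc3ccccc3)[C@H](O)C[C@@H]2O1`, has not yet been measured. Compared with compound 3, (the two compounds have the same atoms and bonds and differ only in configuration as drawn: 1 of 7 stereo elements differ; a stereocentre at a saturated ring carbon is drawn S in compound 3 and R in compound 4). Within the data shown here, no measured pair in this set shows what such an inversion alone does, so there is no step to lean on. The account therefore treats the direction as open: a change in this assay of modest size in either direction, or none beyond the scatter, is plausible. Compound 4 is expected to give about 35 nM in this assay, within a range from 7 nM to 200 nM. The step of a 1.3-fold higher number from compound 3 to compound 4 (0.11 log units; within the scatter) that this estimate implies is expected to be small.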

Compound 4, half-maximal effective concentration: 18 nM
For compound 4 the middle estimate is 1.9-fold (0.29 log units) above the measured one; measured number inside the range.
By their numbers in this assay, from the lowest: compound 2; then compounds 1, 4 and 3 (each within the scatter of the next, the first and the last beyond it).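

Inverting the stereocentre at a saturated ring carbon gives a 1.5-fold lower number from compound 3 to compound 4 (0.18 log units; within the scatter) in this assay, so this read-out does not separate the two configurations at this position. Among these compounds, until this pair, the set held no step between compounds differing in one place, and all the gaps among compounds 1, 2 and 3 came with differences in how the acid-bearing chain is attached. Here, the comparison bears on this single stereocentre and nothing else, and it can be read that way because of the following: the fact that compounds 3 and 4 differ only in the configuration as drawn.

The compounds shown leave open whether the two configurations at this position would still stand within the scatter of each other if the chain carrying the acid were longer, or if a methyl ester took the place of the carboxylic acid. They also leave open whether an inversion of this kind would have so small an effect on the shared side chain and core in the other attachments of the acid-bearing chain, those of compound 1 and compound 2.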